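A few compounds are considered here, and "the series" means these few. Any claim that something is new, unique, unknown or untested is made for them only; others in the source may bear on it.

Within the data shown here, compound 2 `CCCCSc1nc(N)nc2c1ncn2[C@@H]1O[C@H](CO)[C@@H](O)[C@H]1O` carries a butylsulfanyl group on the shared core and in an assay on isolated protein for binding affinity to Equilibrative nucleoside transporter 1 (Homo sapiens) (a higher number here means a weaker inhibitor, a lower number a stronger inhibitor), compound 2 gives 12000 nM, the highest of the two numbers measured so far. Among the measured compounds shown here, its only measured neighbour is compound 1 `Nc1nc(SCc2ccc(Br)cc2)c2ncn([C@@H]3O[C@H](CO)[C@@H](O)[C@H]3O)c2n1`, in which the chain is replaced by a 4-bromobenzyl group; in this assay compound 1 gives 813 nM. For the measured compounds named here, the single step between them, a 15-fold higher number from compound 1 to compound 2 (1.17 log units; beyond the scatter), shows that trading the aromatic ring for a short chain weakens binding substantially.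

Compound 3 `Nc1nc(SCc2ccccc2Cl)c2ncn([C@@H]3O[C@H](CO)[C@@H](O)[C@H]3O)c2n1` has not yet been measured. It differs from compound 2 by 2-chlorophenyl in place of propyl on a saturated chain carbon bound to a sulfur. Going by the values given here, this change is the reverse of the one from compound 1 to compound 2 in kind, putting a halogen-bearing aromatic ring back in place of the propyl chain, though with a different halogen at a different position on the ring. Because a 15-fold higher number from compound 1 to compound 2 (1.17 log units; beyond the scatter) was large, a gain of similar size is expected when the ring returns, so compound 3 is estimated at 1500 nM, within a range of 400 nM to 6000 nM, corresponding to an expected step of an 8.0-fold lower number from compound 2 to compound 3 (0.90 log units; beyond the scatter).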

Compound 3, half-maximal inhibitory concentration: 13500 nM
Compound 3: middle estimate off by 9.0-fold (0.95 log units), on the low side; measured number above the stated range.
By their numbers in this assay, from the lowest: compound 1; then compounds 2 and 3 (each within the scatter of the next).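

In this assay, an aromatic ring in place of the propyl part of the chain is not enough on its own to give a low number: the step is a 1.1-fold higher number from compound 2 to compound 3 (0.05 log units; within the scatter) and leaves compounds 2 and 3 level within the scatter. The comparison between the two ring compounds is far more telling, with a 17-fold higher number from compound 1 to compound 3 (1.22 log units; beyond the scatter) for 2-chlorophenyl in place of 4-bromophenyl on the same saturated chain carbon bound to a sulfur. The advantage of compound 1 over compound 2 therefore belongs to the 4-bromophenyl group specifically and does not extend to every halogen-bearing phenyl ring, and no supporting measurement is available to explain this difference.

The halogen and its place on the ring change together between compound 1 and compound 3, so these compounds cannot show which of the two changes accounts for the large step. A plain benzyl group with no halogen on its ring would show how either halogen-bearing ring compares with the bare ring, and a longer chain such as octyl would show whether chain length alone can change the number.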